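The compounds below may be only part of what the source reports. "The series", "measured", "known", "first", "only" and "open" are said of these compounds alone.

Of the compounds shown here, two sharing one core have been measured in a physicochemical assay, with a stated time of 30 min; on this read-out lower numbers stand for stronger inhibition and higher numbers for weaker inhibition. Compound 1 (`CCc1ccc(NC(=O)C2Cc3cc(OC)c(OC)cc3C2=O)cc1`) gives 76.2 ug/mL. Compound 2 (`COc1ccc(NC(=O)C2Cc3cc(OC)c(OC)cc3C2=O)cc1`) gives 49.5 ug/mL. These two numbers lie within the scatter of each other, so compound 2 stands level with compound 1 and neither can be ranked above the other.

Compound 3 (`CCOc1ccc(NC(=O)C2Cc3cc(OC)c(OC)cc3C2=O)cc1`) departs from compound 2 in one place. The difference is methyl in place of hydrogen on a saturated chain carbon bound to an oxygen on an aromatic ring, which turns methoxy into ethoxy.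

Among the compounds with values here, only one measured step bears on this change, and only indirectly: a 1.5-fold lower number from compound 1 to compound 2 (0.19 log units; within the scatter). Within the data shown here, that step, methoxy in place of ethyl on an aromatic carbon, is a different change, and no measured pair yet shows methoxy going to ethoxy. With so little evidence, no shift beyond the scatter is expected in this assay, and neither direction is favoured. The estimated step is a 1.1-fold higher number from compound 2 to compound 3 (0.05 log units; within the scatter). Compound 3 is expected to give 55 ug/mL, with an estimated range from 27 ug/mL to 110 ug/mL.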

Compound 3, half-maximal inhibitory concentration: 48.2 ug/mL
The estimate for compound 3 lay 1.1-fold (0.06 log units) above the measured number, and the stated range covers the measured number.
By their numbers in this assay, from the lowest: compounds 3, 2 and 1 (each within the scatter of the next).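

The methoxy to ethoxy change now has a direct reading: in this assay the added methyl, placed on a saturated chain carbon bound to an oxygen on an aromatic ring, gives a 1.0-fold lower number from compound 2 to compound 3 (0.01 log units; within the scatter) and leaves compound 3 level with compound 2. The remaining step, a 1.6-fold lower number from compound 1 to compound 3 (0.20 log units; within the scatter), also separates nothing, which means that ethyl, methoxy and ethoxy at this position cannot be ranked against one another on this read-out. Nothing available explains why these groups stand level, and no supporting information bears on this result.

The three compounds do not show whether any group at this position can move the number beyond the scatter, since every step between them lies within it. From the compounds shown here alone, whether a longer chain such as propoxy, or a quite different group such as an amine or a carboxylic acid, would stay level with ethoxy in this assay remains open.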